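Aryl exchange on the amide-type nitrogen of compound 1

A few compounds are considered here, and "the series" means these few. Any claim that something is new, unique, unknown or untested is made for them only; others in the source may bear on it.

Measured compounds:
- Compound 1 `O=C(Nc1cccc(-n2cc(-c3ccncc3)c(-c3ccc(Cl)c(O)c3)n2)c1)Nc1ccc(Cl)c(Cl)c1` gives 4470 nM in a functional assay on KM12 cells (Homo sapiens) for inhibition, read by sulforhodamine B assay, with a stated time of 48 h; on this read-out higher numbers stand for weaker inhibition of growth and lower numbers for stronger inhibition of growth.
- Compound 2 `COc1cc(-c2nn(-c3cccc(NC(=O)c4ccc(Cl)c(C(F)(F)F)c4)c3)cc2-c2ccncc2)ccc1Cl` reaches only a limit of this assay, > 32500 nM.
- Compound 3 `COc1cc(-c2nn(-c3cccc(NC(=O)c4ccccc4)c3)cc2-c2ccncc2)ccc1Cl` likewise reaches only a limit of this assay, > 100000 nM.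

Among the measured compounds shown here, compound 1 thus holds the only number among the three values; the other two are limits. For the measured compounds named here, the one measured step between neighbours, a step that the two limits leave unreadable from compound 2 to compound 3, cannot be read because both ends are limits (the limit of > 100000 nM in this assay, at which 1 of the 3 values shown sits, (the limit of > 32500 nM in this assay, at which 1 of the 3 values shown sits)), so it gives no measure of how an aryl change on the carbonyl side moves growth inhibition.

Compound 4 `O=C(Nc1cccc(-n2cc(-c3ccncc3)c(-c3ccc(Cl)c(O)c3)n2)c1)Nc1cccc(C(F)(F)F)c1` differs from compound 1 by 3-(trifluoromethyl)phenyl in place of 3,4-dichlorophenyl on an amide-type nitrogen. Going by the values given here, no measured step bears on this change: compound 2 and compound 3 vary the aryl on a carbonyl carbon, not on the amide-type nitrogen, and neither yields a number. With nothing in the series to anchor the change, the step from compound 1 to compound 4 is expected to be small, a 1.3-fold higher number from compound 1 to compound 4 (0.13 log units; within the scatter), with wide uncertainty. Compound 4 is therefore estimated at 6000 nM, within a range of 2000 nM to 20000 nM.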

Compound 4, concentration for total growth inhibition: > 32500 nM
Compound 4: only a limit was reported; the forecaster's own chance of this, stated with the estimate: 10%; middle value at least 5.4-fold (0.73 log units) away from the limit.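

In this assay, the aryl on the amide-type nitrogen is not a neutral site: 3-(trifluoromethyl)phenyl in place of 3,4-dichlorophenyl gives an at least 7.2-fold higher number from compound 1 to compound 4 (0.86 log units; beyond the scatter). Among the compounds shown here, this is the only readable step so far, as the step from compound 2 to compound 3 cannot be read and concerned the aryl on a carbonyl carbon. The value of compound 4 is a limit of the assay, not a number: the limit of > 32500 nM in this assay, at which 2 of the 4 values shown sit.

On these data alone, the full size of the step stays open, with compound 4 giving no number. Also open, as far as these compounds go, is whether a cyclohexyl or a pyridyl group on the amide-type nitrogen of the core of compound 1 would give a number in this assay.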